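This account rests on a few compounds, and the source may have more. Where it says the series, first, only, none or still open, it means among the compounds named here.

In a physicochemical assay for lipophilicity, read by HPLC, in phosphate buffer, measured as octanol-water partition, at pH 7.4 (a lower number here means a more polar compound, a higher number a more lipophilic compound), three compounds have been measured so far. Compound 1 `C[C@H](NC(=O)c1ccccc1)C(=O)N(C)/N=N/c1ccc(C#N)cc1` gives 3.04, compound 2 `CC(=O)N[C@@H](C)C(=O)N(C)/N=N/c1ccc(C)cc1` gives 2.45, and compound 3 `CC(=O)NCC(=O)N(C)/N=N/c1ccc(C#N)cc1` gives 1.1. Compound 3 thus stands lowest of the three numbers. The nearest to it is the number of compound 2, which is higher by more than the usual scatter, and the furthest is the number of compound 1, higher still and also well beyond the scatter.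

The step to follow leads from compound 3 to compound 4 `CC(=O)N[C@@H](C)C(=O)N(C)/N=N/c1ccc(C#N)cc1`, which has not yet been measured in this assay. The change between them is methyl in place of hydrogen on a saturated chain carbon bound to an amide-type nitrogen and a carbonyl carbon. Going by the values given here, no two measured compounds differ from each other only by this change, so the size of the step cannot be read directly from a measured pair. Such a small addition of one carbon is generally expected to move the number upward by a modest amount, and the expected step here, a number 0.50 log units higher from compound 3 to compound 4 (beyond the scatter), is a rise in this assay that just exceeds the scatter. Starting from what compound 3 gives, compound 4 is estimated at 1.6, within a range from 1.2 to 2.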

Compound 4, partition coefficient: 1.41
Estimate against measurement, compound 4: 0.19 log units above; the measured number falls inside the stated range.
By their numbers in this assay, from the lowest: compound 3; then compound 4; then compound 2; then compound 1.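

In this assay, methyl in place of hydrogen on a saturated chain carbon bound to an amide-type nitrogen and a carbonyl carbon now has a size that can be read directly: a number 0.31 log units higher from compound 3 to compound 4 (beyond the scatter), a modest rise for the addition of a single carbon. Compound 4 also connects the other two compounds to this pair. Each of them now differs from it in one place: cyano in place of methyl on an aromatic carbon gives a number 1.04 log units lower from compound 2 to compound 4 (beyond the scatter), and methyl in place of phenyl on a carbonyl carbon gives a number 1.63 log units lower from compound 1 to compound 4 (beyond the scatter), so both of these changes produce large steps, while the change at the chain carbon produces a modest one. No measured evidence here explains the size of any of these steps.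

The compounds shown give the methyl step in one setting only, with cyano on the aromatic carbon and methyl on the carbonyl carbon, so its size in other settings remains open. Also open, on these data alone, is how the number would move with a longer chain, an amine or a carboxylic acid on the same chain carbon.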